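The source may hold more compounds than are shown below. What is called first, only, known or untested is meant among the compounds shown, and "the series" means these compounds.

Working notes on the series. Among the compounds with values here, compound 1 (`CCCCCc1cc2c(=O)n(CCC)cnc2s1`) gives 33.8 ug/mL in an ADME assay on MCF7 cells (Homo sapiens) for cytotoxicity, read by MTT assay, with a stated time of 11 days (on this read-out lower numbers stand for stronger inhibition of growth and higher numbers for weaker inhibition of growth), and holds the only actual number so far. Compound 2 (`CCCCCCCc1cc2c(=O)n(CC#N)cnc2s1`) stands at > 100 ug/mL as a limit, not a number. Compound 3 (`CCCCCc1cc2c(=O)n(CC3CC3)cnc2s1`) stands at > 100 ug/mL as a limit as well. Within the data shown here, the set therefore sits largely at the limit of > 100 ug/mL in this assay, at which 2 of the 3 values shown sit, and compound 2 can be placed only there, with no true value to step from.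

Compound 4 (`CCCCCCCc1cc2c(=O)n(CCCBr)cnc2s1`) departs from compound 2 in one place: 2-bromoethyl in place of cyano on a saturated chain carbon bound to an aromatic nitrogen and the same difference, cut one bond further out, reads cyanomethyl to 3-bromopropyl. Among the measured compounds shown here, the one measured step at this place is an at least 2.9-fold higher number from compound 1 to compound 3 (0.47 log units; beyond the scatter) and it is a different exchange, though it shows that this group can move the read-out beyond the scatter. Compound 1, the nearest reference with a plain chain here, reads 33.8 ug/mL but also differs from compound 4 elsewhere on the core. The expected change is an at least 1.6-fold lower number from compound 2 to compound 4 (0.22 log units; that floor lies within the scatter) and is estimated to run toward lower numbers, possibly by no more than the scatter. For compound 4 the estimated value is 60 ug/mL with an expected range from 20 ug/mL to 130 ug/mL and a report as a limit remains quite possible.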

Compound 4, concentration for 50% growth inhibition: 19.7 ug/mL
The estimate for compound 4 lay 3.0-fold (0.48 log units) above the measured number, and the stated range ends above it.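

In this assay, within the data shown here, 2-bromoethyl in place of cyano on a saturated chain carbon bound to an aromatic nitrogen gives an at least 5.0-fold lower number from compound 2 to compound 4 (0.70 log units; beyond the scatter), the first measured step at this place toward lower numbers, whereas the one earlier step, an at least 2.9-fold higher number from compound 1 to compound 3 (0.47 log units; beyond the scatter), ran toward higher numbers. Compound 4 adds a second actual value to the series, 19.7 ug/mL. It also shows that the core of compound 2 is not confined to the limit in this assay, so the group at this place can move the read-out in either direction, on the evidence of these two different exchanges on two different cores. Compound 2 is held at a limit and not a number, and the size of its step is therefore a floor only: the limit of > 100 ug/mL in this assay, at which 2 of the 4 values shown sit.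

The step changes the chain and its end group together, leaving open whether the lower number follows the bromine or the added chain carbons, a question that a plain propyl or a 3-hydroxypropyl group on the core of compound 2 would bear on. As far as these compounds go, compound 1 and compound 4 differ in more than one place, and how the chain at the other site of the core contributes also stays open.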